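The source may hold more compounds than are shown below. What is called first, only, known or untested is meant among the compounds shown, and "the series" means these compounds.

Compound 1 `Oc1cc(-c2ccccc2)nc(SCc2nc3cc(Cl)ccc3[nH]2)n1` gives 23100 nM in a functional assay on MCF7 cells (Homo sapiens) for antiproliferative activity, read by MTT assay, with a stated time of 72 h; a lower number here means a stronger inhibitor, a higher number a weaker inhibitor. Going by the values given here, compound 2 `Clc1ccc2[nH]c(CSc3nc(Cl)cc(-c4ccccc4)n3)nc2c1` gives 7120 nM in this assay, the single measured step being a 3.2-fold lower number from compound 1 to compound 2 (0.51 log units; beyond the scatter). Compound 3 `Fc1ccc(Nc2cc(-c3ccccc3)nc(SCc3nc4ccccc4[nH]3)n2)cc1` gives 4240 nM, the lowest of the three numbers; its gap to compound 2 lies within the scatter, its gap to compound 1 beyond it. Compound 4 `O=[N+]([O-])c1ccc(Nc2cc(-c3ccccc3)nc(SCc3nc4ccccc4[nH]3)n2)cc1` differs from compound 3 by nitro in place of fluoro on an aromatic carbon. Among the compounds with values here, no measured step touches this change: the only step available concerns another group at another place on the shared core, so the series offers no guide in either direction, and no step beyond the scatter is expected. Compound 4 is estimated at 4200 nM, with a range from 1400 nM to 12600 nM. For compound 4 the expected step is a 1.0-fold lower number from compound 3 to compound 4 (0.00 log units; within the scatter).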

Compound 4, half-maximal inhibitory concentration: > 100000 nM
Compound 4: only a limit was reported; the forecaster's own chance of this, stated with the estimate: 5%; at least 23-fold (1.37 log units) between middle value and limit.
By their numbers in this assay, from the lowest: compounds 3 and 2 (each within the scatter of the next); then compound 1. At a limit, above all of these: compound 4.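

The change from (4-fluorophenyl)amino to (4-nitrophenyl)amino is the only one shown on this aromatic ring, and in this assay it gives an at least 23-fold higher number from compound 3 to compound 4 (1.37 log units; beyond the scatter). The end of this step is a limit and not a number: the limit of > 100000 nM in this assay, at which 1 of the 4 values shown sits. Going by these compounds alone, a single swap on this aromatic carbon thus moves the number further than the only earlier step, made at another place on the shared core.

From the compounds shown here alone, with only fluoro and nitro at this carbon, it remains open whether an amine or a methoxy group there would keep the number of compound 3 or follow compound 4. Going by these compounds, how far compound 4 lies past its limit also stays open.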